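The source may hold more compounds than are shown below. What is called first, only, known or untested is meant among the compounds shown, and "the series" means these compounds.

In a functional assay on WI-38 VA13 cells (Homo sapiens) for cytotoxicity (a higher number here means that more compound is needed for the effect, a lower number that less compound is needed), compound 1 (`Cn1ncc([N+](=O)[O-])c1C(=O)Nc1ccc2nc(NC(=O)C3CCCCC3)sc2c1`) gives 0.026 ug/mL, compound 2 (`COc1ccc(C(=O)Nc2ccc3nc(NC(=O)C4CCCCC4)sc3c2)cc1`) gives 4.9 ug/mL, and compound 3 (`N#Cc1ccc(C(=O)Nc2ccc3nc(NC(=O)C4CCCCC4)sc3c2)cc1`) gives 3.3 ug/mL. Compound 3 therefore stands with compound 2, as the data show a 1.5-fold lower number from compound 2 to compound 3 (0.17 log units; within the scatter). It stands far from compound 1, with a 130-fold higher number from compound 1 to compound 3 (2.10 log units; beyond the scatter). The same large gap appears as a 190-fold higher number from compound 1 to compound 2 (2.28 log units; beyond the scatter).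

Compound 4 (`CCC(C)(C)C(=O)Nc1ccc2nc(NC(=O)C3CCCCC3)sc2c1`) has 1,1-dimethylpropyl in place of 4-cyanophenyl on a carbonyl carbon. Going by the values given here, no measured step makes this exchange of a ring for an open chain, so the evidence is only indirect. Both large steps leave the group that compound 1 carries on that carbonyl carbon, and compound 4 does not carry that group. Among the compounds with values here, the one step between compounds that both lack it stays within the scatter. A change within the scatter is therefore expected, with wide uncertainty, and the expected step is a 1.1-fold lower number from compound 3 to compound 4 (0.04 log units; within the scatter). For compound 4 the estimated value is 3 ug/mL, with an expected range of 0.7 ug/mL to 13 ug/mL.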

Compound 4, half-maximal effective concentration: 1 ug/mL
The estimate for compound 4 lay 3.0-fold (0.48 log units) above the measured number, and the stated range covers the measured number.
By their numbers in this assay, from the lowest: compound 1; then compound 4; then compounds 3 and 2 (each within the scatter of the next).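

Exchanging 4-cyanophenyl for 1,1-dimethylpropyl on this carbonyl carbon gives a 3.3-fold lower number from compound 3 to compound 4 (0.52 log units; beyond the scatter) in this assay, and exchanging 4-methoxyphenyl for the same chain gives a 4.9-fold lower number from compound 2 to compound 4 (0.69 log units; beyond the scatter). The number at this position therefore still moves beyond the scatter among compounds without the 1-methyl-4-nitro-1H-pyrazol-5-yl group, and an aromatic ring is not needed there for a lower number. That group nevertheless keeps a wide lead over the open chain, with a 38-fold higher number from compound 1 to compound 4 (1.59 log units; beyond the scatter), so the modest gain closes only part of the gap. Nothing measured here explains these differences.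

On these data alone, how the number would respond to a nitrophenyl group, or to a 1-methyl-1H-pyrazol-5-yl group without the nitro, remains open. The low number of compound 1 therefore cannot yet be assigned to the nitro group or to the pyrazole ring alone.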